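Tolerance of compound 3 in the benzyl nitro series

The compounds below may be only part of what the source reports. "The series", "measured", "known", "first", "only" and "open" are said of these compounds alone.

In an ADME assay on L929 cells (Mus musculus) for cytotoxicity, read by resazurin assay, with a stated time of 48 h; a higher number here means that more compound is tolerated, a lower number that less compound is tolerated:
- compound 1 `N#CCn1c2ccc([N+](=O)[O-])cc2c(=O)n1Cc1ccccc1`: > 256000 nM, a limit
- compound 2 `COC(=O)COc1c2cc([N+](=O)[O-])ccc2nn1Cc1ccccc1`: > 256000 nM, a limit
- compound 3 `O=[N+]([O-])c1ccc2nn(Cc3ccccc3)c(OCCCO)c2c1`: not yet measured

Compound 2 has no number in this assay, only the limit > 256000 nM. Both measured compounds sit at the limit of > 256000 nM in this assay, at which 2 of the 2 values shown sit.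

Compound 3 carries 2-hydroxyethyl in place of methoxycarbonyl on a saturated chain carbon bound to an oxygen on an aromatic ring. No measured step sizes this change. The expected step of an at least 1.2-fold lower number from compound 2 to compound 3 (0.10 log units; that floor lies within the scatter) is none beyond the scatter, with tolerance staying high in this assay. Compound 3 is estimated at 200000 nM, within an expected range of 80000 nM to 256000 nM.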

Compound 3, concentration lethal to 50% of the cells: > 256000 nM
Compound 3 ended at the assay's limit; the forecaster's own chance of this, stated with the estimate: 55%; middle value at least 1.2-fold (0.10 log units) from the limit.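

No step can be read from compound 2 to compound 3, because both values are limits: the limit of > 256000 nM in this assay, at which 3 of the 3 values shown sit.

The compounds shown leave open how much of compound 1, compound 2 or compound 3 is actually tolerated, and whether 2-hydroxyethyl in place of methoxycarbonyl changes tolerance at all.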